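Aryl Sulfonamide Variation in Serotonin Receptor Binding

The source may report more compounds than this note shows. Statements on the series, on what has been measured and on what is new or still open speak of the compounds shown alone.

Three compounds have been measured in an assay on brain for displacement of a labelled ligand from 5-hydroxytryptamine receptor 4 (Cavia porcellus), with a stated time of 30 min, in the presence of a further agent that is not named here; on this read-out lower numbers stand for stronger inhibition and higher numbers for weaker inhibition:

compound 1, `COc1ccc(S(=O)(=O)NCCN2CCC(CCC(=O)c3cc(Cl)c(N)cc3OC)CC2)cc1Cl`: 22.5 nM
compound 2, `COc1ccc(S(=O)(=O)NCCN2CCC(CCC(=O)c3cc(Cl)c(N)cc3OC)CC2)cc1`: 12.3 nM
compound 3, `COc1cc(N)c(Cl)cc1C(=O)CCC1CCN(CCNS(=O)(=O)c2ccc(C)cc2)CC1`: 18 nM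

Compound 3 stands second highest of the three numbers in this assay. Its nearest neighbour is compound 1, a 1.3-fold lower number from compound 1 to compound 3 (0.10 log units; within the scatter); its furthest is compound 2, a 1.5-fold higher number from compound 2 to compound 3 (0.17 log units; within the scatter). All three values sit within the scatter of one another, so no order among them can be claimed.

Compound 4, `COc1ccc(S(=O)(=O)NCCN2CCC(CCC(=O)c3cc(Cl)c(N)cc3OC)CC2)cc1OC`, differs from compound 3 in one place: 3,4-dimethoxyphenyl in place of 4-methylphenyl on a sulfonyl sulfur. Within the data shown here, two measured steps bear on this change. One is a 1.3-fold lower number from compound 1 to compound 3 (0.10 log units; within the scatter), which also exchanges the aryl group on the sulfonyl sulfur; the other is a 1.5-fold higher number from compound 2 to compound 3 (0.17 log units; within the scatter), which exchanges methoxy for methyl on an aromatic carbon of that group. Both lie within the scatter, as does a 1.8-fold lower number from compound 1 to compound 2 (0.26 log units; within the scatter). On these three compounds, changes to the aryl group on the sulfonyl sulfur have not moved this assay beyond its scatter, so compound 4 is expected to show no step beyond the scatter either. Compound 4 is therefore estimated at 16 nM, with a range from 6 nM to 45 nM. This estimate amounts to the step of a 1.1-fold lower number from compound 3 to compound 4 (0.05 log units; within the scatter).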

Compound 4, inhibition constant: 8.2 nM
The estimate for compound 4 lay 2.0-fold (0.29 log units) above the measured number; the measured number falls inside the stated range.
By their numbers in this assay, from the lowest: compounds 4, 2, 3 and 1 (each within the scatter of the next, the first and the last beyond it).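

In this assay the aryl group on the sulfonyl sulfur now gives steps beyond the scatter, though modest ones: 3,4-dimethoxyphenyl in place of 4-methylphenyl gives a 2.2-fold lower number from compound 3 to compound 4 (0.34 log units; beyond the scatter) and methoxy in place of chloro on an aromatic carbon gives a 2.7-fold lower number from compound 1 to compound 4 (0.44 log units; beyond the scatter), whereas no earlier change to this group left the scatter. Methoxy in place of hydrogen on an aromatic carbon gives only a 1.5-fold lower number from compound 2 to compound 4 (0.18 log units; within the scatter), so compound 2 and compound 4 cannot be told apart and the added methoxy alone carries no claim. Nothing available accounts for these steps.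

Going by these compounds, whether ethoxy in place of methoxy, or an amine in place of chloro on an aromatic carbon, would give steps of this size remains open. So does whether the 3,4-dimethoxyphenyl step would hold on any core other than the shared one.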